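Ring-substituted oxindole acrylates: HL-60 cytotoxicity notes

The source may hold more compounds than are shown below. What is called first, only, known or untested is meant among the compounds shown, and "the series" means these compounds.

Measured so far in a functional assay on HL-60 cells (Homo sapiens) for cytotoxicity, read by CCK-8 assay, with a stated time of 72 h; a higher number here means a weaker inhibitor, a lower number a stronger inhibitor:
compound 1 `CC(C)(C)OC(=O)/C=C1/C(=O)Nc2ccccc21` gives 2450 nM
compound 2 `CCCCc1ccc2c(c1)/C(=C\C(=O)OC(C)(C)C)C(=O)N2` gives 6190 nM
compound 3 `COc1ccc2c(c1)/C(=C\C(=O)OC(C)(C)C)C(=O)N2` gives 6190 nM

Compound 1, the unsubstituted parent, carries the lowest number of the three in this assay. Both substituted analogs sit higher: a 2.5-fold higher number from compound 1 to compound 2 (0.40 log units; beyond the scatter) and a 2.5-fold higher number from compound 1 to compound 3 (0.40 log units; beyond the scatter), while no change at the digits printed from compound 2 to compound 3 (within the scatter). So far every substituent placed on the aromatic ring has cost a modest amount.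

Compound 4 `CC(C)(C)OC(=O)/C=C1/C(=O)Nc2c(Cl)cccc21` is the next step from compound 1: chloro in place of hydrogen on an aromatic carbon. For the measured compounds named here, no measured pair shows a chloro group, and no measured pair shows a substituent at this place ortho to the fused ring, so the bearing steps are only the two ring substitutions from compound 1, each a modest rise. Taken together they suggest that a further aromatic substituent is more likely to raise the number than lower it, though a step within the scatter cannot be excluded. The expected step is therefore a 1.6-fold higher number from compound 1 to compound 4 (0.21 log units; within the scatter), a modest rise. Compound 4 is thus estimated at 4000 nM in this assay, with a range from 1500 nM to 11000 nM.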

Compound 4, half-maximal inhibitory concentration: 6120 nM
Compound 4: middle estimate off by 1.5-fold (0.18 log units), on the low side, and the stated range covers the measured number.
By their numbers in this assay, from the lowest: compound 1; then compounds 4, 2 and 3 (each within the scatter of the next).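

Chloro on an aromatic carbon ortho to a fused ring gives the first reading at this place and for this group in this assay, with a 2.5-fold higher number from compound 1 to compound 4 (0.40 log units; beyond the scatter). The rise matches in printed size those for the two earlier ring substitutions, a 2.5-fold higher number from compound 1 to compound 2 (0.40 log units; beyond the scatter) and a 2.5-fold higher number from compound 1 to compound 3 (0.40 log units; beyond the scatter), so among the compounds shown, compound 1 keeps the lowest number and no ring substituent goes against that pattern. Nothing available explains why the chloro step has this size, and no measurement separates the effect of the group from that of its place.

Still open, on these data alone, is whether fluoro, an amine or a carboxylic acid at this same place would also raise the number. Also open, as far as these compounds go, is whether chloro at the place held by butyl in compound 2 would give a different step from compound 1.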